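Sulfur-linked azole swap on the shared core

A few compounds are considered here, and "the series" means these few. Any claim that something is new, unique, unknown or untested is made for them only; others in the source may bear on it.

Two measured compounds carry the shared core and differ only in the group on the sulfur. Compound 1 `Cn1c(-c2ccc(NC(=O)CSc3nc4cc(Cl)ccc4o3)cc2)nc(-c2ccccc2)c1-c1ccccc1` gives 2.4% in a functional assay on MCF7 cells (Homo sapiens) for cytotoxicity, read by MTT assay, with a stated time of 24 h, tested at 0.64 ug/mL; on this read-out lower numbers stand for a weaker effect and higher numbers for a stronger effect at the one concentration tested. Going by the values given here, compound 2 `Cn1cnnc1SCC(=O)Nc1ccc(-c2nc(-c3ccccc3)c(-c3ccccc3)n2C)cc1` gives 33.1% in this assay, the higher of the two numbers; its only neighbour is compound 1, and the single measured step is a number 30.7 percentage points higher from compound 1 to compound 2 (beyond the scatter), a large one. Compound 3 `Cn1nnnc1SCC(=O)Nc1ccc(-c2nc(-c3ccccc3)c(-c3ccccc3)n2C)cc1` is not yet measured. Its difference from compound 2: 1-methyl-1H-tetrazol-5-yl in place of 4-methyl-4H-1,2,4-triazol-3-yl on a sulfur. Among the compounds with values here, no measured step covers this particular exchange; the step from compound 1 to compound 2 concerns a different ring on the same sulfur and gives no guide to the size of the present one. With nothing in the numbers to push the value either way, the expected step is a number 3.1 percentage points lower from compound 2 to compound 3 (within the scatter), none beyond the scatter. For compound 3 the estimate in this assay is 30%, with a range of 14% to 46%.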

Compound 3, a percentage reported as activity, at one concentration (the size of the read-out at that concentration, not a potency): 21.9%
Beside the measured number, compound 3's estimate is 8.1 percentage points above it; low and high end bracket the measured number.
By their numbers in this assay, from the lowest: compound 1; then compound 3; then compound 2.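

In this assay, the ring on the sulfur matters even between two closely matched azoles: 1-methyl-1H-tetrazol-5-yl in place of 4-methyl-4H-1,2,4-triazol-3-yl, an exchange of a ring carbon for a ring nitrogen, gives a number 11.2 percentage points lower from compound 2 to compound 3 (beyond the scatter). 1-Methyl-1H-tetrazol-5-yl in place of 5-chloro-1,3-benzoxazol-2-yl gives a number 19.5 percentage points higher from compound 1 to compound 3 (beyond the scatter), so among these compounds both methylated azoles stand clear of the chlorinated benzoxazole, with no compound against that order. Nothing available accounts for these differences.

Still open, on these data alone, is how a group of another kind on the sulfur, such as an aminoethyl chain or a carboxylic acid, would read in this assay. Also open, as far as these compounds go, is whether the order of the three compounds would hold at other concentrations.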